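Swapping a Dichlorobenzyl Arm for a Methoxybenzyl Arm

The source may hold more compounds than are shown below. What is called first, only, known or untested is meant among the compounds shown, and "the series" means these compounds.

Measured compounds:
compound 1, `CCOC(=O)[C@H](CCC(=O)O)NC(=O)c1ccc(CNc2nc3cc(N)cc(N)c3nc2-c2ccccc2)cc1`, < 100000 nM
compound 2, `Nc1cc(N)c2nc(-c3ccccc3)c(NCc3ccc(Cl)c(Cl)c3)nc2c1`, 19100 nM
compound 3, `CCOC(=O)[C@H](CCC(=O)O)NC(=O)c1ccc(Sc2nc3cc(N)cc(N)c3nc2-c2ccccc2)cc1`, < 100000 nM

Three compounds share a core and were tested in a functional assay on PC-3 cells (Homo sapiens) for inhibition, read by sulforhodamine B assay, with a stated time of 48 h; on this read-out higher numbers stand for lower toxicity in this test and lower numbers for higher toxicity in this test. For compound 1 the value < 100000 nM is a limit of the assay, not a number. For compound 3 the value < 100000 nM is likewise a limit. Among the compounds with values here, compound 2 therefore gives the only true number, 19100 nM, while the other two sit at the limit of < 100000 nM in this assay, at which 2 of the 3 values shown sit.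

Compound 4, `COc1ccc(CNc2nc3cc(N)cc(N)c3nc2-c2ccccc2)cc1`, has not been measured. It differs from compound 2 by one change: 4-methoxyphenyl in place of 3,4-dichlorophenyl on a saturated chain carbon bound to a nitrogen on an aromatic ring. Within the data shown here, with no measured pair showing what this swap does, only a modest step is expected, probably toward less toxicity; the expected change from compound 2 to compound 4 is a 2.1-fold higher number from compound 2 to compound 4 (0.32 log units; beyond the scatter). Compound 4 is estimated at 40000 nM, within 10000 nM to 100000 nM.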

Compound 4, concentration lethal to 50% of the cells: 72400 nM
For compound 4 the middle estimate is 1.8-fold (0.26 log units) below the measured one; the measured number falls inside the stated range.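

Within the data shown here, replacing 3,4-dichlorobenzyl with 4-methoxybenzyl gives a 3.8-fold higher number from compound 2 to compound 4 (0.58 log units; beyond the scatter) in this assay and so shows, for the first time here, that this arm can shift the read-out toward lower toxicity in this test. Among these compounds, this is the only comparison between two true numbers, as the other compounds remain limits: the limit of < 100000 nM in this assay, at which 2 of the 4 values shown sit.

Both chlorine atoms leave and the methoxy group enters in one step, so the two effects cannot be separated. On these data alone, what an amine or a nitrile would do on this arm stays open.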